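The source may report more compounds than this note shows. Statements on the series, on what has been measured and on what is new or still open speak of the compounds shown alone.

In a functional assay on DU-145 cells (Homo sapiens) for antiproliferative activity, read by sulforhodamine B assay, with a stated time of 72 h (on this read-out lower numbers stand for stronger inhibition of growth and higher numbers for weaker inhibition of growth), compound 1, with the structure `CCc1cc(=O)c2ccc(Sc3cccc(Cl)[n+]3[O-])cc2o1`, gives > 29900 nM, which is a limit of the assay rather than a number. Compound 2, `CCc1cc(=O)c2ccc(Sc3cccc(Cl)[n+]3[O-])c(C)c2o1`, carries methyl in place of hydrogen on an aromatic carbon and gives > 28700 nM in this assay, again a limit. The step that the two limits leave unreadable from compound 1 to compound 2 therefore cannot be read, because both values rest at a limit, the limit of > 29900 nM in this assay, at which 1 of the 3 values shown sits, and (the limit of > 28700 nM in this assay, at which 1 of the 3 values shown sits). Compound 3, `CCc1cc(=O)c2ccc(Sc3cccc(Cl)n3)cc2o1`, has a different core; how its core differs from that of compound 1 is not broken down here. In this assay compound 3 gives > 31400 nM, also a limit. Compound 4, `CCc1cc(=O)c2ccc(Sc3cccc(Cl)n3)c(C)c2o1`, is not yet measured and carries methyl in place of hydrogen on an aromatic carbon. This is the same kind of change as that from compound 1 to compound 2, though the surroundings differ slightly: in compound 2 the methyl sits ortho to a group of 9 heavy atoms, in compound 4 ortho to a group of 8 heavy atoms. The step that the limit leaves unreadable from compound 3 to compound 4 is expected to be small, because compound 3 sits at a limit, (the limit of > 31400 nM in this assay, at which 1 of the 3 values shown sits), and the earlier step left no readable size. Compound 4 is expected to give about 35000 nM, most likely again only a limit, within 15000 nM to 100000 nM.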

Compound 4, concentration for 50% growth inhibition: > 30100 nM
Compound 4 gave a limit, no number; the forecaster's own chance of this, stated with the estimate: 85%; the middle value is on the limit's open side.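

Compound 3 and compound 4 both rest at a limit of the assay, so the step between them, methyl in place of hydrogen on an aromatic carbon, cannot be read. The compounds shown leave open how strongly any of them inhibits growth and whether this methyl changes that inhibition at all.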